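Removing the 2-chlorobenzyl Group from Compound 1

The compounds below may be only part of what the source reports. "The series", "measured", "known", "first", "only" and "open" are said of these compounds alone.

In a functional assay on MDA-MB-231 cells (Homo sapiens) for cytotoxicity, read by MTT assay, with a stated time of 72 h (a higher number here means a weaker inhibitor, a lower number a stronger inhibitor), compound 1 (`CN(C)Cc1ccc2nc(NC(=O)N/N=C/c3cn(Cc4ccccc4Cl)c4ccccc34)sc2c1`) gives 1180 nM as its half-maximal inhibitory concentration. Compound 3 (`Cc1ccc(Cn2cc(/C=N/NC(=O)Nc3nc4ccc(CN5CCC(C)CC5)cc4s3)c3ccccc32)cc1`) gives 1140 nM in the same test, and the two stand level within the usual scatter. Compound 2 (`CN(C)Cc1ccc2nc(NC(=O)N/N=C3\C(=O)Nc4ccc(F)cc43)sc2c1`) adds no number, as its entry reads "not determined" (no result reported) here. Among the measured compounds shown here, compound 1 therefore shares the only measured position with compound 3.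

Compound 4 (`CN(C)Cc1ccc2nc(NC(=O)N/N=C/c3c[nH]c4ccccc34)sc2c1`), not yet measured, has hydrogen in place of 2-chlorobenzyl on an aromatic nitrogen. For the measured compounds named here, no measured pair shows this change alone, so the expectation is tentative. Going by the values given here, compound 1 at 1180 nM and compound 3 at 1140 nM both carry a benzyl group on that nitrogen, and compound 4 would be the first reading without one. A moderate move to a higher number, meaning a weaker inhibitor, is expected in this assay. The expected step is a 2.5-fold higher number from compound 1 to compound 4 (0.41 log units; beyond the scatter) in size. For compound 4 the estimated value is 3000 nM within an expected range from 1000 nM to 10000 nM in this test.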

Compound 4, half-maximal inhibitory concentration: 1190 nM
Compound 4: the middle estimate sits 2.5-fold (0.40 log units) above what was measured; measured number inside the range.
By their numbers in this assay, from the lowest: compounds 3, 1 and 4 (each within the scatter of the next).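

In this assay, hydrogen in place of 2-chlorobenzyl on the aromatic nitrogen amounts to a 1.0-fold higher number from compound 1 to compound 4 (0.00 log units; within the scatter), so the two compounds stand level. The earlier compounds shown here all carried a benzyl group on this nitrogen, whereas this pair shows that, on the core of compound 1, the whole 2-chlorobenzyl group can be exchanged for hydrogen without a difference this test can resolve. No supporting measurement is at hand to say why the number holds.

Only hydrogen and benzyl groups are shown on this nitrogen, so it remains open whether a methyl group, a longer chain, or a chain ending in an amine or a carboxylic acid would also read level. The compounds shown also leave open whether the exchange for hydrogen would read the same on the core of compound 3.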